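Tolerance of Compound 4 in HeLa Cells

The source may report more compounds than this note shows. Statements on the series, on what has been measured and on what is new or still open speak of the compounds shown alone.

Measured in a toxicity assay on HeLa cells (Homo sapiens) for cytotoxicity; a higher number here means that more compound is tolerated, a lower number that less compound is tolerated:
- compound 1 `COc1nc(C2CCCCC2)ccc1[C@@H](c1ccccc1)[C@@](O)(CCN(C)C)c1cccc2ccccc12`: 57.7 ug/mL
- compound 2 `COc1nc(-c2ccc(F)cc2)ccc1[C@@H](c1ccccc1)[C@@](O)(CCN(C)C)c1cccc2ccccc12`: > 64 ug/mL (a limit)
- compound 3 `COc1nc(-c2ccc(C#N)cc2)ccc1[C@@H](c1ccccc1)[C@@](O)(CCN(C)C)c1cccc2ccccc12`: > 64 ug/mL (a limit)

Compound 3 has no number, only the limit > 64 ug/mL. This is the limit of > 64 ug/mL in this assay, at which 2 of the 3 values shown sit.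

Compound 4 `COc1nc(C2CCOCC2)ccc1[C@@H](c1ccccc1)[C@@](O)(CCN(C)C)c1cccc2ccccc12` carries oxan-4-yl in place of 4-cyanophenyl on an aromatic carbon.

Among the compounds with values here, three measured steps bear on this change. The step of an at least 1.1-fold higher number from compound 1 to compound 3 (0.04 log units; that floor lies within the scatter) and the step of an at least 1.1-fold higher number from compound 1 to compound 2 (0.04 log units; that floor lies within the scatter) both show floors only, and the step that the two limits leave unreadable from compound 2 to compound 3 cannot be sized. Compound 1 carries cyclohexyl at this place, the closest measured group to oxan-4-yl, and gives 57.7 ug/mL. On that basis, no step beyond the scatter is expected in this assay, although the true size stays hidden behind the limit. The expected change is an at least 1.0-fold lower number from compound 3 to compound 4 (0.02 log units; that floor lies within the scatter). For compound 4 the estimated value is 60 ug/mL, with an expected range from 35 ug/mL to 100 ug/mL.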

Compound 4, half-maximal cytotoxic concentration: 22.5 ug/mL
Compound 4: middle estimate off by 2.7-fold (0.43 log units), on the high side; the whole stated range lies above it.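

In this assay, this place next to the ring nitrogen now shows a step beyond the scatter, and it arises between two non-aromatic six-membered rings: oxan-4-yl in place of cyclohexyl gives a 2.6-fold lower number from compound 1 to compound 4 (0.41 log units; beyond the scatter). Oxan-4-yl also falls clearly short of both aromatic groups, with an at least 2.8-fold lower number from compound 3 to compound 4 (0.45 log units; beyond the scatter) and an at least 2.8-fold lower number from compound 2 to compound 4 (0.45 log units; beyond the scatter), so the earlier floors alone did not show that a change here could lower the number beyond the scatter. These last two steps are floors, since compound 2 and compound 3 each stand at a limit: the limit of > 64 ug/mL in this assay, at which 2 of the 4 values shown sit.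

As far as these compounds go, the step between compound 2 and compound 3 cannot be read, so the effect of nitrile against fluoro on the phenyl ring stays unknown. The compounds shown also leave open whether piperidin-4-yl, which carries a ring nitrogen instead of the oxygen of oxan-4-yl, would stay close to compound 1 or compound 4.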